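The source may report more compounds than this note shows. Statements on the series, on what has been measured and on what is new or still open speak of the compounds shown alone.

Measured in a functional assay on K562 cells (Homo sapiens), read by MTT assay, with a stated time of 72 h; a lower number here means a stronger inhibitor, a higher number a weaker inhibitor:
- Compound 1 `Nc1nc(N)c2c(-c3ccsc3)cn([C@@H]3O[C@H](CO)[C@@H](O)[C@H]3O)c2n1`: > 20000 nM
- Compound 2 `Cc1nc(N)c2c(-c3cccs3)cn([C@@H]3O[C@H](CO)[C@@H](O)[C@H]3O)c2n1`: > 20000 nM
- Compound 3 `Cc1nc(N)c2c(-c3ccsc3)cn([C@@H]3O[C@H](CO)[C@@H](O)[C@H]3O)c2n1`: > 20000 nM

Each of these entries is a limit of the assay and not a number. Compound 3 therefore has no exact place in the series, and the picture is the limit of > 20000 nM in this assay, at which 3 of the 3 values shown sit. The next compound, compound 4 `Cc1nc(N)c2c(I)cn([C@@H]3O[C@H](CO)[C@@H](O)[C@H]3O)c2n1`, carries iodo in place of thiophen-3-yl on an aromatic carbon. Two measured steps lead to compound 3, and neither has a readable size. One is a step that the two limits leave unreadable from compound 1 to compound 3. The other, closer to the site of the new change, is a step that the two limits leave unreadable from compound 2 to compound 3. Among the measured compounds shown here, no measured step removes the thiophene, so the data give no size for this exchange. In this assay, for the measured compounds named here, the expectation is therefore of no defined step and no firm direction, with compound 4 likely to stay near the same limit, although a measurable value remains possible. The expected outcome is an at least 1.1-fold lower number from compound 3 to compound 4 (0.04 log units; that floor lies within the scatter). The estimate for compound 4 is 18000 nM. The expected range for compound 4 runs from 4000 nM to 40000 nM.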

Compound 4, half-maximal inhibitory concentration: 1110 nM
The estimate for compound 4 lay 16-fold (1.21 log units) above the measured number; the measured number lies below the stated range.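

Iodo in place of thiophen-3-yl gives an at least 18-fold lower number from compound 3 to compound 4 (1.25 log units; beyond the scatter) and iodo in place of thiophen-2-yl gives an at least 18-fold lower number from compound 2 to compound 4 (1.25 log units; beyond the scatter) in this assay so this aromatic carbon is a place where a single change can bring the read-out away from the limit. Both steps start from a limit, so each gives a smallest size and not an exact one, while the steps among the thiophene compounds cannot be read. Compound 4 is the only compound shown with an exact number, and the others remain limits: the limit of > 20000 nM in this assay, at which 3 of the 4 values shown sit.

As far as these compounds go, whether bromo, chloro or a plain hydrogen on this carbon would give a number like that of compound 4 stays open. Also open, from the compounds shown here alone, is whether an amino group in place of the methyl of compound 4 would keep that number.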